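Fluorophenyl position shift on two related quinolone cores

This account rests on a few compounds, and the source may have more. Where it says the series, first, only, none or still open, it means among the compounds named here.

Measured so far in a functional assay on Hep 3B2 cells (Homo sapiens) for cytotoxicity, read by MTT assay, with a stated time of 48 h; on this read-out higher numbers stand for weaker inhibition and lower numbers for stronger inhibition:
- compound 1 `COc1ccc2[nH]c(-c3ccccc3F)cc(=O)c2c1OC`: > 20000 nM
- compound 2 `COc1ccc2[nH]c(-c3cccc(F)c3)cc(=O)c2c1OC`: 2600 nM
- compound 3 `COc1cc2c(=O)cc(-c3ccccc3F)[nH]c2cc1O`: 5300 nM

The value of compound 1 is a limit of this assay, not a number (the limit of > 20000 nM in this assay, at which 1 of the 3 values shown sits). Compound 2 differs from compound 1 by 3-fluorophenyl in place of 2-fluorophenyl on an aromatic carbon, and this step gives an at least 7.6-fold lower number from compound 1 to compound 2 (0.88 log units; beyond the scatter). Compound 3 carries a different core; the difference between the two cores is not broken down here. Compound 3 stands with the highest number of the two that are not limits, with compound 2 nearest.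

Compound 4 `COc1cc2c(=O)cc(-c3cccc(F)c3)[nH]c2cc1O` has not yet been measured. It differs from compound 3 by 3-fluorophenyl in place of 2-fluorophenyl on an aromatic carbon, the same change as from compound 1 to compound 2. Because the first step gave an at least 7.6-fold lower number from compound 1 to compound 2 (0.88 log units; beyond the scatter), the step for compound 4 in this assay is expected to be a 6.6-fold lower number from compound 3 to compound 4 (0.82 log units; beyond the scatter). Compound 4 is therefore estimated at 800 nM, most likely between 250 nM and 2500 nM.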

Compound 4, half-maximal inhibitory concentration: 5300 nM
Compound 4: middle estimate off by 6.6-fold (0.82 log units), on the low side, outside the stated range (above it).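

The change to 3-fluorophenyl from 2-fluorophenyl gives no change at the digits printed from compound 3 to compound 4 (within the scatter) in this assay. The same change therefore does not carry over unchanged between these two cores in this assay: the same change on two cores in this assay, an at least 7.6-fold lower number (0.88 log units; beyond the scatter) from compound 1 to compound 2 and no change at the digits printed (within the scatter) from compound 3 to compound 4, at least 7.6-fold (0.88 log units) apart, beyond the scatter of two such steps. Compound 1 gives > 20000 nM, which is a limit of the assay and not a number, so the size of its step stays open, and this single pair of cores gives neither a reason for the difference nor a rule for any other core.

Which difference between the two cores accounts for the split remains open. Also open, on these data alone, is how each core responds when the fluorine on the phenyl ring is replaced by an amine or a carboxylic acid.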